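This account rests on a few compounds, and the source may have more. Where it says the series, first, only, none or still open, it means among the compounds named here.

Compound 1 `CC(C)N(Cc1cccc(OCCCCCC(=O)O)c1)C(=O)c1ccc(-c2cccc(N(C)C)c2)cc1` gives > 26000 nM in an ADME assay on Raji cells (Homo sapiens) for cytotoxicity, read by CellTiter-Glo and resazurin assay, with a stated time of 72 h (a lower number here means that less compound is needed, a higher number that more compound is needed for the effect), a limit of the assay.
Compound 2 `CC(=O)Nc1cccc(-c2ccc(C(=O)N(Cc3cccc(OCCCCCC(=O)O)c3)C(C)C)cc2)c1` gives > 26000 nM in this assay, again a limit.
Compound 3 `CC(C)N(Cc1cccc(OCCCCCC(=O)O)c1)C(=O)c1ccc(-c2ccoc2)cc1` gives > 26000 nM in this assay, also a limit.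

Compound 2 stands where every value shown stands: at the limit of > 26000 nM in this assay, at which 3 of the 3 values shown sit, so that nothing distinguishes it from the other two on the numbers at hand. The unmeasured compound 4 `CC(C)N(Cc1cccc(OCCCCCC(=O)O)c1)C(=O)c1ccc(-c2ccc3cc[nH]c3c2)cc1` differs from it in one place: 1H-indol-6-yl in place of 3-acetamidophenyl on an aromatic carbon.

Going by the values given here, two measured steps touch the same position. The step that the two limits leave unreadable from compound 1 to compound 2 and the step that the two limits leave unreadable from compound 2 to compound 3 both run between limits, and neither gives a readable size or direction. The aryl group at this position has been varied three ways without any compound leaving the limit, so the numbers offer no reason to expect a step beyond the scatter in this assay from the change to compound 4, in either direction. Compound 4 is therefore expected to give 30000 nM, with an estimated range from 15000 nM to 60000 nM. The estimated step that the limit leaves unreadable from compound 2 to compound 4 is expected to stay within the scatter, most likely as another limit.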

Compound 4, half-maximal effective concentration: > 26000 nM
Compound 4: no number, only a limit; the forecaster's own chance of this, stated with the estimate: 85%; the middle value is on the limit's open side.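

In this assay compound 4 gives > 26000 nM, again a limit of the assay. Its steps to compound 1, compound 2 and compound 3 cannot be read. The compounds shown leave open whether any group at this position would give an actual number in this assay.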